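From Phenyl to 2,4-Difluorophenyl in an Antiproliferative Series

The compounds below may be only part of what the source reports. "The series", "measured", "known", "first", "only" and "open" are said of these compounds alone.

In a functional assay on MDA-MB-436 cells (Homo sapiens) for antiproliferative activity, read by MTT assay, with a stated time of 48 h (on this read-out lower numbers stand for stronger inhibition and higher numbers for weaker inhibition), compound 1 (`C=CS(=O)(=O)N1CCN(c2ccn3ncc(-c4ccccc4)c3n2)CC1`) stands at 19500 nM as its half-maximal inhibitory concentration and compound 3 (`CN1CCN(c2ccc(-c3cc4c(N5CCN(C(=O)Nc6ccccc6)CC5)ncnc4s3)cc2)CC1`) at 7090 nM on the same read-out. Compound 2 (`C=CS(=O)(=O)N1CCN(c2ncnc3sc(C4=CCCCC4)cc23)CC1`) returns a limit of the assay (> 50000 nM) and no number. Compound 3 therefore holds the lower of the two true numbers, a gap from compound 1 that lies beyond the scatter. Compound 4 (`CN1CCN(c2ccc(-c3cc4c(N5CCN(C(=O)Nc6ccc(F)cc6F)CC5)ncnc4s3)cc2)CC1`) differs from compound 3 by 2,4-difluorophenyl in place of phenyl on an amide-type nitrogen. Going by the values given here, no measured pair shows this kind of change, so only a small shift is expected in this assay, leaning slightly towards lower numbers. Expected is a step of a 1.3-fold lower number from compound 3 to compound 4 (0.11 log units; within the scatter) that stays within the scatter. The estimate puts compound 4 at 5500 nM with an expected range (2500 nM to 14000 nM).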

Compound 4, half-maximal inhibitory concentration: 20200 nM
Estimate against measurement, compound 4: 3.7-fold (0.56 log units) below; the measured number lies above the stated range.
By their numbers in this assay, from the lowest: compound 3; then compounds 1 and 4 (each within the scatter of the next). At a limit, above all of these: compound 2.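

In this assay, 2,4-difluorophenyl in place of phenyl on the amide-type nitrogen gives a 2.8-fold higher number from compound 3 to compound 4 (0.45 log units; beyond the scatter) and moves the read-out towards weaker inhibition. Going by these compounds alone, the earlier compounds held no pair differing in one place, so this is the first sign that the group on this nitrogen can shift the read-out at all. Nothing shown here gives a cause for this step. Still open, as far as these compounds go, is whether 2-fluorophenyl or 4-fluorophenyl alone would shift the read-out in the same way, and how a pyridyl or 4-methoxyphenyl group would read on the same nitrogen.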